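This account rests on a few compounds, and the source may have more. Where it says the series, first, only, none or still open, it means among the compounds named here.

Measured compounds in an assay on isolated protein for binding affinity to Gonadotropin-releasing hormone receptor (Homo sapiens); on this read-out higher numbers stand for weaker inhibition and lower numbers for stronger inhibition:
compound 1 `Cc1cc2c(cc1Cc1ccc(C(=O)NC[C@H]3CC[C@H](C(=O)O)CC3)o1)C(C)(C)CCC2(C)C` gives 250 nM
compound 2 `Cc1ccc(CNC(=O)c2ccc(Cc3cc4c(cc3C)C(C)(C)CCC4(C)C)o2)cc1` gives 83 nM
compound 3 `Cc1cc2c(cc1Cc1ccc(C(=O)NCC3CCC(CN)CC3)o1)C(C)(C)CCC2(C)C` gives 42 nM

Compound 3 sits at the low end of the three numbers in this assay. The step of a 2.0-fold lower number from compound 2 to compound 3 (0.30 log units; within the scatter) means those two cannot be separated, while the step of a 6.0-fold lower number from compound 1 to compound 3 (0.77 log units; beyond the scatter) is real.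

Compound 4 `Cc1cc2c(cc1Cc1ccc(C(=O)NCC3CCN(C(=N)N)CC3)o1)C(C)(C)CCC2(C)C` is unmeasured. It differs from compound 3 by a group of 9 heavy atoms (6 carbon, 3 nitrogen; one six-membered non-aromatic ring with 1 hetero atom) in place of a group of 8 heavy atoms (7 carbon, 1 nitrogen; one six-membered non-aromatic ring of carbon only), on a saturated chain carbon bound to an amide-type nitrogen. The measured steps at this position are the replacements on the chain carbon bound to the amide nitrogen: a 3.0-fold lower number from compound 1 to compound 2 (0.48 log units; beyond the scatter) and a 6.0-fold lower number from compound 1 to compound 3 (0.77 log units; beyond the scatter) both move away from the carboxy group, and a 2.0-fold lower number from compound 2 to compound 3 (0.30 log units; within the scatter) shows that the aminomethylcyclohexyl and the methylphenyl groups give indistinguishable numbers. The change to compound 4 keeps a ring of similar size and keeps hydrogen-bond donors, with no carboxy group entering, so no step beyond the scatter is expected; the estimated step is a 1.1-fold lower number from compound 3 to compound 4 (0.02 log units; within the scatter), essentially flat. Compound 4 is therefore expected at about 40 nM, with a range of 15 nM to 120 nM.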

Compound 4, inhibition constant: 220 nM
Compound 4: the middle estimate sits 5.5-fold (0.74 log units) below what was measured; measured number above the stated range.
By their numbers in this assay, from the lowest: compounds 3 and 2 (each within the scatter of the next); then compounds 4 and 1 (each within the scatter of the next).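

In this assay, keeping a six-membered non-aromatic ring and hydrogen-bond donors on the saturated chain carbon bound to an amide-type nitrogen does not preserve the number: the change gives a 5.2-fold higher number from compound 3 to compound 4 (0.72 log units; beyond the scatter) and, against the 4-methylphenyl group, a 2.7-fold higher number from compound 2 to compound 4 (0.42 log units; beyond the scatter) as well. The new group also reads level with the 4-carboxycyclohexyl group, with only a 1.1-fold lower number from compound 1 to compound 4 (0.06 log units; within the scatter) separating them, so the 4-carboxycyclohexyl group no longer stands apart at this position. Nothing measured here accounts for this result.

The compounds shown leave open whether the ring nitrogen or the group it carries sets the step from compound 3 to compound 4. On these data alone, how a longer chain ending in a primary amine would read at this position also remains open.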